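The source may hold more compounds than are shown below. What is called first, only, known or untested is meant among the compounds shown, and "the series" means these compounds.

Three analogues sharing one core have been tested in a functional assay on MCF7 cells (Homo sapiens) for cytotoxicity, read by MTT assay, with a stated time of 48 h; a higher number here means a weaker inhibitor, a lower number a stronger inhibitor. Compound 1 `Cc1ccc(/C=C2/S/C(=N/c3ccccc3)N(Cc3ccncc3)C2=O)cc1` gives 36900 nM. Compound 2 `O=C1/C(=C\c2ccc(Cl)cc2)S/C(=N/c2ccccc2)N1Cc1ccncc1` gives 54900 nM, and compound 3 `CN(C)c1ccc(/C=C2/S/C(=N/c3ccccc3)N(Cc3ccncc3)C2=O)cc1` gives 76300 nM. Compound 2 thus holds the second highest of the three numbers; its gap to compound 3 is a 1.4-fold higher number from compound 2 to compound 3 (0.14 log units; within the scatter) and its gap from compound 1 is a 1.5-fold higher number from compound 1 to compound 2 (0.17 log units; within the scatter), both within the scatter, whereas a 2.1-fold higher number from compound 1 to compound 3 (0.32 log units; beyond the scatter) is a modest step just beyond it. The unmeasured compound 4 `CCOc1cc(/C=C2/S/C(=N/c3ccccc3)N(Cc3ccncc3)C2=O)ccc1O` differs from compound 2 by 3-ethoxy-4-hydroxyphenyl in place of 4-chlorophenyl on a double-bonded chain carbon bound to a double-bonded ring carbon. All three measured steps bear on this, since each alters a substituent on an aromatic carbon, and none moved this assay by more than a modest amount. The present change exchanges the whole aryl group, so a somewhat larger move is conceivable, but no direction is indicated by the data. Compound 4 is therefore expected in this assay to give an estimated 50000 nM, ranging from 15000 nM to 160000 nM. The step expected is a 1.1-fold lower number from compound 2 to compound 4 (0.04 log units; within the scatter).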

Compound 4, half-maximal inhibitory concentration: 20100 nM
The estimate for compound 4 lay 2.5-fold (0.40 log units) above the measured number; the measured number falls inside the stated range.
By their numbers in this assay, from the lowest: compounds 4, 1, 2 and 3 (each within the scatter of the next, the first and the last beyond it).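

In this assay, 3-ethoxy-4-hydroxyphenyl is the only group shown on this double-bonded chain carbon that gives a lower number than two of the others by more than the scatter: a 2.7-fold lower number from compound 2 to compound 4 (0.44 log units; beyond the scatter) and a 3.8-fold lower number from compound 3 to compound 4 (0.58 log units; beyond the scatter). Against 4-methylphenyl, however, a 1.8-fold lower number from compound 1 to compound 4 (0.26 log units; within the scatter) leaves compound 4 not separable from compound 1, so the group cannot be called better than every other one shown. The change also shows that a larger aryl group of 10 heavy atoms, carrying a hydrogen-bond donor, can stand here without raising the number, though nothing available explains the shift.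

From the compounds shown here alone, the ethoxy and hydroxy groups enter together, so their separate contributions remain open. Also open, going by these compounds, is how a lone hydroxy group, a lone ethoxy group, a longer alkoxy chain or a carboxylic acid would read here.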